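The compounds below may be only part of what the source reports. "The series", "measured", "known", "first", "only" and "open" are said of these compounds alone.

Of the compounds shown here, two of a shared core have been measured so far: compound 1, `O=C(NCc1cc(Cl)ccc1-n1cnnn1)[C@@H]1CC=NN1C(=O)[C@H](O)C1CCCCC1`, and compound 2, `CC(C)CC[C@@H](O)C(=O)N1N=CC[C@H]1C(=O)NCc1cc(Cl)ccc1-n1cnnn1`. In an ADME assay on Caco-2 cells (Homo sapiens) for permeability, read by LC-MS, in the apical to basolateral direction, with a stated time of 60 min, at pH 6.5 (on this read-out higher numbers stand for higher permeability and lower numbers for lower permeability), compound 1 gives 19 10^-6 cm/s, and compound 2 gives 29 10^-6 cm/s. Among the measured compounds shown here, the one measured step between them, a 1.5-fold higher number from compound 1 to compound 2 (0.18 log units; within the scatter), is isopentyl in place of cyclohexyl on a saturated chain carbon bound to a carbonyl carbon and an oxygen on a saturated carbon. For the measured compounds named here, compound 2 stands at the top of these two numbers, with compound 1 its only neighbour, and the gap between them lies within the scatter, so the two are not told apart.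

Compound 3 is `O=C(NCc1cc(Cl)ccc1-n1cnnn1)[C@@H]1CC=NN1C(=O)[C@H](O)Cc1ccccc1`. The change from compound 2 to compound 3 is phenyl in place of isobutyl on a saturated chain carbon, two bonds along the chain from a carbonyl carbon and an oxygen on a saturated carbon. Going by the values given here, only one earlier step bears on it, a 1.5-fold higher number from compound 1 to compound 2 (0.18 log units; within the scatter), which also exchanged the group on this chain and stayed within the scatter. Because a 1.5-fold higher number from compound 1 to compound 2 (0.18 log units; within the scatter) stayed within the scatter, the expected step in this assay is a 1.2-fold lower number from compound 2 to compound 3 (0.06 log units; within the scatter), none beyond the scatter. Compound 3 is therefore estimated at 25 10^-6 cm/s, within a range from 12 10^-6 cm/s to 50 10^-6 cm/s.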

Compound 3, apparent permeability: 11 10^-6 cm/s
Estimate against measurement, compound 3: 2.3-fold (0.36 log units) above; measured number outside the range, below it.
By their numbers in this assay, from the lowest: compounds 3, 1 and 2 (each within the scatter of the next, the first and the last beyond it).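

This position on the chain responds to the group it carries in this assay: phenyl in place of isobutyl gives a 2.6-fold lower number from compound 2 to compound 3 (0.42 log units; beyond the scatter), a modest step but the first in this set to go beyond the scatter. The other new step, a 1.7-fold lower number from compound 1 to compound 3 (0.24 log units; within the scatter), stays within the scatter, so benzyl and cyclohexyl on this chain carbon are not told apart, and compound 1 lies within the scatter of both other compounds, leaving only the highest and lowest numbers separated. No measurement available here accounts for the difference between the open chain and the aromatic ring.

All three groups compared here are made of carbon only, and a single step beyond the scatter cannot show whether the lower number goes with the aromatic ring itself or only with this particular exchange. A pyridine ring, an amine or a carboxylic acid at the end of this chain, or a longer chain ending in phenyl, would show how far the trend seen here extends.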